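Isopropoxy to Dimethylcarbamoyl: Expecting Compound 4

This account rests on a few compounds, and the source may have more. Where it says the series, first, only, none or still open, it means among the compounds named here.

Of the compounds shown here, three have been measured in a functional assay for agonist activity at G protein-coupled receptor 88 (Homo sapiens), read by HTRF and cAMP accumulation; a higher number here means that more compound is needed for the effect, a lower number that less compound is needed. Compound 1 `CCC(CC)C(N)CCN(C(=O)[C@@H]1C[C@H]1c1ccccc1)c1ccc(-c2ccccc2)cc1` gives 2 nM, compound 2 `CC[C@H](C)[C@H](N)CN(C(=O)[C@@H]1C[C@H]1c1ccncc1)c1ccc(-c2ccccc2)cc1` gives 1500 nM, and compound 3 `CC[C@H](C)[C@H](N)CN(C(=O)[C@@H]1C[C@H]1c1ccccc1)c1ccc(-c2ccc(OC(C)C)cc2)cc1` gives 72 nM. Compound 3 therefore stands second highest of the three numbers: compound 2 sits well above it, beyond the scatter, while compound 1 sits well below it, also beyond the scatter. Compound 4 `CC[C@H](C)[C@H](N)CN(C(=O)[C@@H]1C[C@H]1c1ccccc1)c1ccc(-c2ccc(C(=O)N(C)C)cc2)cc1` has not yet been measured. It differs from compound 3 in a single place: dimethylcarbamoyl in place of isopropoxy on an aromatic carbon. Among the compounds with values here, no measured pair shows this same change, so the step can only be estimated. The expected step is a modest rise, a 1.7-fold higher number from compound 3 to compound 4 (0.22 log units; within the scatter), close to the edge of the scatter. Compound 4 is expected to give about 120 nM, with a likely range from 30 nM to 500 nM.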

Compound 4, half-maximal effective concentration: 980 nM
The estimate for compound 4 lay 8.2-fold (0.91 log units) below the measured number; measured number outside the range, above it.
By their numbers in this assay, from the lowest: compound 1; then compound 3; then compounds 4 and 2 (each within the scatter of the next).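

In this assay, within the data shown here, the swap of isopropoxy for dimethylcarbamoyl on this aromatic carbon, para to a large group, gives a 14-fold higher number from compound 3 to compound 4 (1.13 log units; beyond the scatter) as the first step here between compounds that differ in one place. This position is therefore sensitive to what sits on it, even though neither group brings a ring, a net charge or a hydrogen-bond donor. Nothing measured here explains the step.

From the compounds shown here alone, whether a methoxy group, a primary amide or a carboxylic acid at this position would stay nearer compound 3 remains open. So does whether the same swap would cost as much on the core of compound 1.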